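A Methyl Step Repeated on a Second Core

A few compounds are considered here, and "the series" means these few. Any claim that something is new, unique, unknown or untested is made for them only; others in the source may bear on it.

Compound 1 `CN(CC1CCC/C(=C\c2ccccc2)C1=O)c1ccccc1` and compound 2 `Cc1ccc(N(C)CC2CCC/C(=C\c3ccccc3)C2=O)cc1` share one core and differ in a single place, namely (methyl in place of hydrogen on an aromatic carbon). In a functional assay on the whole organism (strain Kunming) for inhibition, with Mus musculus as the target, in the writhing test, with stated times of 1 h and 15 min, at a dose of 200 mg/kg by the oral route (on this read-out higher numbers stand for more inhibition at the one dose given (going by the name of the read-out) and lower numbers for less inhibition), compound 1 gives 69.7%, and in this assay compound 2 gives 81%; that single change thus made a number 11.3 percentage points higher from compound 1 to compound 2 (beyond the scatter).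

Compound 3 `COc1ccc(C2(O)/C(=C/c3ccccc3)CCCC2CN(C)c2ccccc2)cc1` is built on another core, carrying a hydroxyl and a methoxyphenyl group that the first two compounds lack; the difference between the two cores is not broken down here. In this assay compound 3 gives 75.7%, a number within the scatter of compound 2 and also within the scatter of compound 1, so no order among these three is drawn from it.

Compound 4 `COc1ccc(C2(O)/C(=C/c3ccccc3)CCCC2CN(C)c2ccc(C)cc2)cc1` has not yet been measured. It differs from compound 3 by methyl in place of hydrogen on an aromatic carbon. The place of the entering methyl is described in the same words for both pairs, so this is the same change made on the second core rather than a merely similar one.

For compound 4 a step of a number 8.3 percentage points higher from compound 3 to compound 4 (within the scatter) in this assay is expected, because the identical change from compound 1 to compound 2 gave a number 11.3 percentage points higher from compound 1 to compound 2 (beyond the scatter). Among the measured compounds shown here, since only one such pair exists, the estimate rests on one observation and is held loosely. Compound 4 is therefore expected to give about 84% in this assay. For compound 4 the expected range runs from 71% to 96%.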

Compound 4, a percentage reported as inhibition, in the whole organism at one dose (the size of the read-out at that dose, not a potency): 78.7%
Compound 4: middle estimate off by 5.3 percentage points, on the high side; measured number inside the range.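

On the second core, the methyl in place of hydrogen on an aromatic carbon gave in this assay a number 3 percentage points higher from compound 3 to compound 4 (within the scatter), so this step alone cannot be told from no change. Set beside the step on the first core, it does not differ from it by more than the scatter allows, and the two pairs can be read as one effect of similar size: the same change on two cores in this assay, a number 11.3 percentage points higher (beyond the scatter) from compound 1 to compound 2 and a number 3 percentage points higher (within the scatter) from compound 3 to compound 4, 8.3 percentage points apart, within the scatter of two such steps. Among the compounds shown here, this shows that the change carries to the second core without any detectable difference in its step, but it does not show that the methyl raises inhibition on that core, nor that the step there is as large as on the first core, since only the pair on the first core lies beyond the scatter and the comparison rests on just two pairs at a single dose.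

The compounds shown leave open whether a longer chain such as ethyl, or a halogen such as chlorine, in the same place on the aromatic ring would follow the methyl on either core. They also leave open whether moving the methyl to another carbon of that ring would give a step that could be read on the second core.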